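Expecting a value for the 4-ethylpiperazin-1-yl compound

The compounds below may be only part of what the source reports. "The series", "measured", "known", "first", "only" and "open" are said of these compounds alone.

- compound 1 `CN(C[C@H]1Cc2c(cccc2N2CCNC(C)(C)C2)CN1)[C@H]1CCCc2cccnc21`: 100%
- compound 2 `CN(C[C@H]1Cc2c(cccc2N2CCN3CCC[C@@H]3C2)CN1)[C@H]1CCCc2cccnc21`: 52.2%

Both numbers come from an ADME assay on microsomes from liver (Homo sapiens) for metabolic stability, read by LC-MS, with a stated time of 10 min; a lower number here means that less of the compound is left, a higher number that more of the compound is left. Compound 2 has the lower of the two values, at 52.2%, and the gap to compound 1 is beyond the scatter.

The next compound is compound 3 `CCN1CCN(c2cccc3c2C[C@H](CN(C)[C@H]2CCCc4cccnc42)NC3)CC1`. It differs from compound 2 in one group, on an aromatic carbon of the shared core: a group of 8 heavy atoms (6 carbon, 2 nitrogen; one six-membered non-aromatic ring with 2 hetero atoms) in place of a group of 9 heavy atoms (7 carbon, 2 nitrogen; one five-membered non-aromatic ring with 1 hetero atom, one six-membered non-aromatic ring with 2 hetero atoms), on an aromatic carbon. The group that enters is 4-ethylpiperazin-1-yl.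

Going by the values given here, only one measured step bears on this change: a number 47.8 percentage points lower from compound 1 to compound 2 (beyond the scatter). It is a large step, and it went the opposite way in group size, from the smaller group to the larger one. Among the compounds with values here, compound 3 has the same counted size as compound 1 in this group, but the two groups are not the same, and no measured compound carries 4-ethylpiperazin-1-yl. Within the data shown here, with the step of a number 47.8 percentage points lower from compound 1 to compound 2 (beyond the scatter) as the only guide, only part of that drop is expected to return, and the uncertainty is wide.

The expected step is a number 9.8 percentage points higher from compound 2 to compound 3 (within the scatter). The estimate for compound 3 is 62%, with an expected range from 38% to 88%.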

Compound 3, percent of the compound remaining: 0%
Beside the measured number, compound 3's estimate is 62 percentage points above it; the measured number lies below the stated range.
By their numbers in this assay, from the lowest: compound 3; then compound 2; then compound 1.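

In this assay, 4-ethylpiperazin-1-yl on this aromatic carbon gives a number 52.2 percentage points lower from compound 2 to compound 3 (beyond the scatter) and does not bring back what was lost with the larger two-ring group. The comparison with 3,3-dimethylpiperazin-1-yl is sharper still, with a number 100 percentage points lower from compound 1 to compound 3 (beyond the scatter) even though the two groups have the same count of heavy atoms, carbon and nitrogen, so two groups of equal counted size can give very different numbers here, and group size alone does not put these compounds in order: compound 3 carries the smaller group than compound 2 yet has the lower number. No measurement shown here explains why the number changes so sharply between these groups.

The compounds shown leave open whether the change from compound 1 to compound 3 follows from the ethyl group, from the loss of the two methyl groups, or from both together. A plain piperazin-1-yl group or a 4-methylpiperazin-1-yl group at this place, tested in the same way on the shared core, would help to separate these possibilities.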